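A few compounds are considered here, and "the series" means these few. Any claim that something is new, unique, unknown or untested is made for them only; others in the source may bear on it.

Compound 1 (`Cc1cc(S(=O)(=O)N2C=CNC(=O)[C@H]2CC(=O)N[C@H]2CCN(C)CC2(C)C)c(C)cc1Cl`) and compound 2 (`Cc1cc(S(=O)(=O)N2C=CNC(=O)[C@H]2CC(=O)N2CCCCC(N(C)C)CC2)c(C)cc1Cl`) share one core and differ only in the group on a carbonyl carbon. In an in vitro ADME assay on microsomes from liver (Homo sapiens) for pharmacokinetics (a higher number here means faster removal of the compound, a lower number slower removal), compound 1 gives 87 mL.min-1.g-1 and compound 2 gives 60 mL.min-1.g-1 as its reading, so compound 2 stands level with compound 1 within the usual scatter. Compound 3 (`Cc1cc(S(=O)(=O)N2C=CNC(=O)[C@H]2CC(=O)N2CCC3(CCN(C)C3)C2)c(C)cc1Cl`) has not yet been measured. It keeps the same core, and the change from compound 2 is a group of 10 heavy atoms (8 carbon, 2 nitrogen; 2 five-membered non-aromatic rings with 1 hetero atom each) in place of a group of 11 heavy atoms (9 carbon, 2 nitrogen; one eight-membered non-aromatic ring with 1 hetero atom), on a carbonyl carbon with everything else left as it was.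

Going by the values given here, only one measured step bears on this change (a 1.5-fold lower number from compound 1 to compound 2 (0.16 log units; within the scatter)). That step exchanged a group with one six-membered non-aromatic ring for the group with one eight-membered non-aromatic ring at the same carbonyl carbon. Among the compounds with values here, no measured compound yet carries the two five-membered non-aromatic rings, so this single step is a thin guide. Even so, no step beyond the scatter is expected in this assay on this evidence. The estimate amounts to a 1.1-fold higher number from compound 2 to compound 3 (0.03 log units; within the scatter) as the expected step. Compound 3 is expected at 65 mL.min-1.g-1 with an estimated range from 30 mL.min-1.g-1 to 130 mL.min-1.g-1 for its measurement.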

Compound 3, intrinsic clearance in microsomes: 28 mL.min-1.g-1
Compound 3: middle estimate off by 2.3-fold (0.37 log units), on the high side; the whole stated range lies above it.
By their numbers in this assay, from the lowest: compound 3; then compounds 2 and 1 (each within the scatter of the next).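

Going by these compounds alone, until now, in this assay, the only comparison at this position was a change of the group on the carbonyl carbon that stayed within the scatter, so the position could have seemed insensitive to such changes. The group with 2 five-membered non-aromatic rings shows otherwise: it gives a 2.1-fold lower number from compound 2 to compound 3 (0.33 log units; beyond the scatter), and also a 3.1-fold lower number from compound 1 to compound 3 (0.49 log units; beyond the scatter), which leaves compound 3 the most slowly removed of the three, although both steps are modest. The groups of compound 1 and compound 3 each have 10 heavy atoms, 8 carbon and 2 nitrogen, so the atom count alone does not fix the result, and the way those atoms are arranged in rings makes a measurable difference here.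

The data on hand offer no explanation for why the number falls with this group. On these data alone, it also remains open whether this lower number is specific to the group in compound 3 or would also appear with another group on the same carbonyl carbon, such as a piperazine or a morpholine.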